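Cytotoxicity at the assay ceiling across the series

The compounds below may be only part of what the source reports. "The series", "measured", "known", "first", "only" and "open" are said of these compounds alone.

Three analogues sharing one core carry values in an ADME assay on Huh-7 cells (Homo sapiens) for cytotoxicity; a lower number here means that less compound is tolerated, a higher number that more compound is tolerated. Compound 1 `CN1CCN(CCNCc2cn(-c3ccc(F)cc3F)nc2Cc2ccccc2)CC1` gives only a limit, > 20000 nM. Compound 3 `CN1CCN(CCNCc2cn(-c3ccc(F)cc3F)nc2C2CCCCC2)CC1` also reaches only a limit, > 20000 nM. Compound 2 `Cc1ccccc1-c1nn(Cc2ccc(F)cc2)cc1CNCCN1CCN(C)CC1` likewise stops at a limit, > 20000 nM. Among the compounds with values here, the one pair that differs in a single place, cyclohexyl in place of benzyl on an aromatic carbon, gives a step that the two limits leave unreadable from compound 1 to compound 3, so its size cannot be read; the limit of > 20000 nM in this assay, at which 3 of the 3 values shown sit, is the only evidence the series offers. Within the data shown here, compound 2 therefore stands where every value so far stands, at the ceiling of this assay with no number of its own.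

Compound 4 `Cc1ccccc1-c1nn(-c2ccc(Br)cc2)cc1CNCCN1CCN(C)CC1` is not yet measured. It differs from compound 2 by 4-bromophenyl in place of 4-fluorobenzyl on an aromatic nitrogen. Among the measured compounds shown here, no measured step touches this position or this exchange, so nothing here bears on it in size or direction. For the measured compounds named here, the only guide is that all three measured compounds sit at the limit. Compound 4 is therefore expected to sit there as well, an estimated 25000 nM with a range of 12000 nM to 50000 nM. The step involved is expected to be a step that the limit leaves unreadable from compound 2 to compound 4, which is none beyond the scatter.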

Compound 4, half-maximal cytotoxic concentration: 9600 nM
The estimate for compound 4 lay 2.6-fold (0.42 log units) above the measured number; measured number outside the range, below it.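

Notes on the aromatic nitrogen: this is the first position in the series where this assay gives a readable change, with 4-bromophenyl in place of 4-fluorobenzyl giving an at least 2.0-fold lower number from compound 2 to compound 4 (0.31 log units; beyond the scatter). One end of this step is a limit, so only its minimum can be read and the full size may be larger. Compound 4 is also the only compound shown with a number of its own, so tolerance in this series is no longer uniformly at the ceiling, and the earlier compounds could not show this: the limit of > 20000 nM in this assay, at which 3 of the 4 values shown sit.

As far as these compounds go, the exchange changes the halogen and replaces benzyl with phenyl in a single step, so whether bromine or the loss of the benzyl carbon goes with the lower number stays open; 4-bromobenzyl or 4-fluorophenyl on the same nitrogen would separate the two. From the compounds shown here alone, whether 4-chlorophenyl or 4-methoxyphenyl at this position gives a similar number is also open, and the other step, between compounds that both sit at the limit, cannot be read.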